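Swapping Morpholinyl for Piperidinyl on a Methylated Core

A few compounds are considered here, and "the series" means these few. Any claim that something is new, unique, unknown or untested is made for them only; others in the source may bear on it.

Three compounds have so far been measured in a functional assay on HeLa cells (Homo sapiens) for cytotoxicity, read by MTT assay, with a stated time of 72 h, tested at 10 uM; a higher number here means more inhibition of growth at the concentration tested, a lower number less inhibition of growth:

Compound 1 `N/C(=N\NC(=S)N1CCOCC1)c1ccccn1` gives 56.3%.
Compound 2 `N/C(=N\NC(=S)N1CCCCC1)c1ccccn1` gives 55.7%.
Compound 3 `Cc1cccc(/C(N)=N/NC(=S)N2CCOCC2)n1` gives 85.4%.

Compound 1 and compound 2 share one core and differ in a single place: piperidin-1-yl in place of morpholin-4-yl on a thiocarbonyl carbon. That exchange changed the read-out by a number 0.6 percentage points lower from compound 1 to compound 2 (within the scatter), so the two values cannot be told apart. Compound 3 differs from compound 1 in a different place, on the core itself: methyl in place of hydrogen on an aromatic carbon. This step, a number 29.1 percentage points higher from compound 1 to compound 3 (beyond the scatter), makes compound 3 the highest of the three measured values, with its steps to compound 1 and compound 2 both beyond the scatter.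

Compound 4 `Cc1cccc(/C(N)=N/NC(=S)N2CCCCC2)n1` has not yet been measured in this assay. It differs from compound 3 in exactly the way compound 2 differs from compound 1: piperidin-1-yl in place of morpholin-4-yl on a thiocarbonyl carbon. The place of the exchange is the same in both pairs, a thiocarbonyl carbon whose other neighbour is an amide-type nitrogen, so this is the same change carried onto the methylated core; how the two cores differ is the methyl-for-hydrogen difference told above.

Because the earlier exchange a number 0.6 percentage points lower from compound 1 to compound 2 (within the scatter) stayed within the scatter, the same exchange on the methylated core is expected to leave the read-out about where compound 3 stands. The step is estimated at a number 1.4 percentage points lower from compound 3 to compound 4 (within the scatter). Compound 4 is therefore expected to give 84%, with a likely range from 72% to 94%.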

Compound 4, percent growth inhibition at one concentration: 83.5%
Compound 4: middle estimate off by 0.5 percentage points, on the high side; measured number inside the range.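

In this assay, piperidin-1-yl in place of morpholin-4-yl on the methylated core changed the read-out by a number 1.9 percentage points lower from compound 3 to compound 4 (within the scatter), which matches the same exchange on the core without the methyl: the same change on two cores in this assay, a number 0.6 percentage points lower (within the scatter) from compound 1 to compound 2 and a number 1.9 percentage points lower (within the scatter) from compound 3 to compound 4, 1.3 percentage points apart, within the scatter of two such steps. The methyl-for-hydrogen change also carried over when the piperidin-1-yl group was present, raising the read-out by a number 27.8 percentage points higher from compound 2 to compound 4 (beyond the scatter), again close to the earlier step: the same change on two cores in this assay, a number 29.1 percentage points higher (beyond the scatter) from compound 1 to compound 3 and a number 27.8 percentage points higher (beyond the scatter) from compound 2 to compound 4, 1.3 percentage points apart, within the scatter of two such steps. Within these four compounds, each change therefore had about the same effect whichever form the other place took, but this does not show that the agreement extends to other cores, other exchanges or other cell lines, and it does not explain why the methyl step is large while the ring exchange stays within the scatter.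

These compounds leave open whether the thiocarbonyl carbon would tolerate other amines just as well, such as piperazin-1-yl, which carries a second ring nitrogen, or an open-chain dimethylamino group. They also leave open whether an ethyl group or a chlorine atom in place of the methyl on the aromatic carbon would give a similar rise.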